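A few compounds are considered here, and "the series" means these few. Any claim that something is new, unique, unknown or untested is made for them only; others in the source may bear on it.

In a functional assay on HT-29 cells (Homo sapiens) for cytotoxicity, read by MTT assay, with a stated time of 72 h (a lower number here means a stronger inhibitor, a higher number a weaker inhibitor), the three measured compounds share one core and differ only in the group on the carbonyl carbon. Compound 1 `CCc1ccc(C(=O)NC[C@H]2c3[nH]c4ccccc4c3C[C@H]3[C@H]4c5[nH]c6ccccc6c5C[C@@H]([C@H](C#N)N23)N4C)cc1` gives 3560 nM, compound 2 `CN1[C@@H]2c3[nH]c4ccccc4c3C[C@H]1[C@H](C#N)N1[C@@H](CNC(=O)c3ccc4ccccc4n3)c3[nH]c4ccccc4c3C[C@@H]21` gives 150 nM, and compound 3 `CN1[C@@H]2c3[nH]c4ccccc4c3C[C@H]1[C@H](C#N)N1[C@@H](CNC(=O)c3cc4ccccc4o3)c3[nH]c4ccccc4c3C[C@@H]21` gives 850 nM, which places compound 3 second highest of the three, nearer to compound 1 than to compound 2. The change to compound 4 `CN1[C@@H]2c3[nH]c4ccccc4c3C[C@H]1[C@H](C#N)N1[C@@H](CNC(=O)/C=C/c3cccc(C(F)(F)F)c3)c3[nH]c4ccccc4c3C[C@@H]21` is 2-(3-(trifluoromethyl)phenyl)ethenyl in place of 1-benzofuran-2-yl on a carbonyl carbon. The earlier steps shown here at this same carbon were a 24-fold lower number from compound 1 to compound 2 (1.38 log units; beyond the scatter), a 4.2-fold lower number from compound 1 to compound 3 (0.62 log units; beyond the scatter) and a 5.7-fold higher number from compound 2 to compound 3 (0.75 log units; beyond the scatter), so the group here can shift the number well beyond the scatter in either direction. Going by the values given here, no measured step covers an open-chain ethenyl group, so the direction is uncertain, and the estimate for compound 4 is 1200 nM within 250 nM to 6000 nM. That would be a step of a 1.4-fold higher number from compound 3 to compound 4 (0.15 log units; within the scatter), expected to fall within the scatter.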

Compound 4, half-maximal inhibitory concentration: 5060 nM
For compound 4 the middle estimate is 4.2-fold (0.62 log units) below the measured one; the range from low to high includes it.
By their numbers in this assay, from the lowest: compound 2; then compound 3; then compounds 1 and 4 (each within the scatter of the next).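

In this assay, the open-chain 2-(3-(trifluoromethyl)phenyl)ethenyl group on the carbonyl carbon loses ground against 1-benzofuran-2-yl, with a 6.0-fold higher number from compound 3 to compound 4 (0.77 log units; beyond the scatter), and against quinolin-2-yl, with a 34-fold higher number from compound 2 to compound 4 (1.53 log units; beyond the scatter). It cannot be separated from 4-ethylphenyl, with a 1.4-fold higher number from compound 1 to compound 4 (0.15 log units; within the scatter), so this position now shows two groups with clearly lower numbers and two that stay together at higher ones. Nothing available explains this difference. Open, from the compounds shown here alone, is whether the ethenyl link or the trifluoromethyl group carries the change, and how an amine or a carboxylic acid in its place would read.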